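This account rests on a few compounds, and the source may have more. Where it says the series, first, only, none or still open, it means among the compounds named here.

Series values in a physicochemical assay for lipophilicity; on this read-out lower numbers stand for lower lipophilicity and higher numbers for higher lipophilicity:

- compound 1 `CC(C)c1cc(Cl)cc(C(C)C)c1O`: 5.34
- compound 2 `CC(C)c1cc(I)cc(C(C)C)c1O`: 5.75
- compound 3 `CC(C)c1cc([N+](=O)[O-])cc(C(C)C)c1O`: 4.71

Compound 3 holds the lowest of the three numbers, and compound 1 is the nearest to it. The next change gives compound 4 `COS(=O)(=O)c1cc(C(C)C)c(O)c(C(C)C)c1`, with methoxysulfonyl in place of nitro on an aromatic carbon, para to a hydroxy group: methoxysulfonyl in place of nitro on an aromatic carbon.

Within the data shown here, no measured step involves methoxysulfonyl, so the evidence is indirect. Three swaps at this place bear on it: the modest a number 0.41 log units higher from compound 1 to compound 2 (beyond the scatter), the modest a number 0.63 log units lower from compound 1 to compound 3 (beyond the scatter) and the large a number 1.04 log units lower from compound 2 to compound 3 (beyond the scatter). They show that the group at this place can move the number well beyond the scatter, but they say nothing directly about the entering group. Only a small downward shift is therefore expected, quite possibly none beyond the scatter.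

The expected step is a number 0.21 log units lower from compound 3 to compound 4 (within the scatter). For compound 4 the estimated value is 4.5, with an expected range from 4 to 5.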

Compound 4, partition coefficient: 3.7
Estimate against measurement, compound 4: 0.80 log units above; the whole stated range lies above it.
By their numbers in this assay, from the lowest: compound 4; then compound 3; then compound 1; then compound 2.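

In this assay, methoxysulfonyl takes the series below all three earlier groups at this position, on an aromatic carbon para to the hydroxy group: the change reads a number 1.01 log units lower from compound 3 to compound 4 (beyond the scatter), a number 1.64 log units lower from compound 1 to compound 4 (beyond the scatter) and a number 2.05 log units lower from compound 2 to compound 4 (beyond the scatter). Nitro therefore no longer marks the low end of what this position can give, and the swap from iodo to methoxysulfonyl is now the widest step in the series. No measurement shown accounts for the size of this drop.

Open, on these data alone, is where a carboxylic acid, an amine or a methylsulfonyl group at this place would fall relative to compound 4 in this assay. Also open, as far as these compounds go, is whether the same order of groups holds when a longer chain replaces the two isopropyl groups on the shared core.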